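The source may report more compounds than this note shows. Statements on the series, on what has been measured and on what is new or still open speak of the compounds shown alone.

Measured in an ADME assay on NHDF cells (Homo sapiens) for cytotoxicity, read by MTT assay, with a stated time of 72 h; a higher number here means a weaker inhibitor, a lower number a stronger inhibitor:
Compound 1 `COc1cccc(/C=C2\CCC/C(=C\c3ccc(O)cc3)C2=O)c1OC` gives only the assay limit, > 50000 nM.
Compound 2 `COc1cc(/C=C2\CCC/C(=C\c3cccc(OC)c3OC)C2=O)ccc1O` gives 14300 nM.
Compound 3 `COc1ccc(/C=C2\CCC/C(=C\c3ccc(OC)c(OC)c3)C2=O)cc1` gives 30900 nM.
Compound 4 `COc1ccc(/C=C2\CCC/C(=C\c3ccc(OC)c(OC)c3)C2=O)cc1OC` is not yet measured.

Compound 1 and compound 2 differ by methoxy in place of hydrogen on an aromatic carbon, and in this assay that gave an at least 3.4-fold lower number from compound 1 to compound 2 (0.54 log units; beyond the scatter). The value of compound 1 is a limit (the limit of > 50000 nM in this assay, at which 1 of the 3 values shown sits). Compound 3 differs from compound 1 in more than one place; the difference between the two cores is not broken down here. Compound 4 differs from compound 3 by methoxy in place of hydrogen on an aromatic carbon, the same kind of change, though here the entering methoxy sits ortho to a methoxy group rather than ortho to a hydroxy group. Going by the values given here, for compound 4 a lower number is expected, with a step of about a 2.6-fold lower number from compound 3 to compound 4 (0.41 log units; beyond the scatter), resting on an at least 3.4-fold lower number from compound 1 to compound 2 (0.54 log units; beyond the scatter) as the one step of this kind seen. The estimate for compound 4 in this assay is 12000 nM, between 5000 nM and 30000 nM.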

Compound 4, half-maximal inhibitory concentration: 9700 nM
Beside the measured number, compound 4's estimate is 1.2-fold (0.09 log units) above it, within the range that was stated.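

In this assay, methoxy in place of hydrogen on an aromatic carbon gives a 3.2-fold lower number from compound 3 to compound 4 (0.50 log units; beyond the scatter), and the earlier pair points the same way: the same change on two cores in this assay, an at least 3.4-fold lower number (0.54 log units; beyond the scatter) from compound 1 to compound 2 and a 3.2-fold lower number (0.50 log units; beyond the scatter) from compound 3 to compound 4; the limit leaves it open whether they differ.
Compound 1 gives only a limit, so the earlier step has no fixed size: the limit of > 50000 nM in this assay, at which 1 of the 4 values shown sits.
The direction of the change therefore carries across these two cores, but equal size is not shown, and two pairs do not establish a rule for the series.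

Still open, going by these compounds, is whether an ethoxy group, an amine or a carboxylic acid in the same place would shift the number in the same direction. Also open, on these data alone, is whether the methoxy step holds on cores beyond these two.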